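This account rests on a few compounds, and the source may have more. Where it says the series, first, only, none or still open, it means among the compounds named here.

Compound 1 `CN(C)CCn1cnnc1-c1cc(Oc2ccc(NC(=O)N/N=C/c3ccccc3O[N+](=O)[O-])cc2F)ccn1` and compound 2 `CN(C)CCn1cnnc1-c1cc(Oc2ccc(NC(=O)N/N=C/c3ccc(F)cc3F)cc2F)ccn1` share one core and differ at the carbon with a double bond to nitrogen. In an ADME assay on WI-38 cells (Homo sapiens) for cytotoxicity, read by MTT assay, with a stated time of 72 h (a higher number here means a weaker inhibitor, a lower number a stronger inhibitor), compound 1 gives 6860 nM. In this assay compound 2 gives 5030 nM. Among the measured compounds shown here, the step of a 1.4-fold lower number from compound 1 to compound 2 (0.13 log units; within the scatter) is the one measured step, and it lies within the scatter, so compound 2 and compound 1 cannot be told apart on these numbers; compound 2 simply stands beside compound 1.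

Compound 3 `CN(C)CCn1cnnc1-c1cc(Oc2ccc(NC(=O)N/N=C/c3c(O)ccc4ccccc34)cc2F)ccn1` carries the change (2-hydroxynaphthalen-1-yl in place of 2,4-difluorophenyl on a carbon with a double bond to nitrogen). For the measured compounds named here, the measured step that bears on it is the one from compound 1 to compound 2, which exchanged a group at the same place and did not move the number beyond the scatter. On that single precedent, a change at this place is expected to leave this assay about where it stands, with no step beyond the scatter in either direction, so the step of a 1.1-fold higher number from compound 2 to compound 3 (0.04 log units; within the scatter) is expected to be small. Compound 3 is therefore estimated at 5500 nM, with a range from 2500 nM to 12000 nM.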

Compound 3, half-maximal inhibitory concentration: 3250 nM
The estimate for compound 3 lay 1.7-fold (0.23 log units) above the measured number, within the range that was stated.
By their numbers in this assay, from the lowest: compounds 3, 2 and 1 (each within the scatter of the next, the first and the last beyond it).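

Among the compounds shown here, at the carbon with a double bond to nitrogen, 2-hydroxynaphthalen-1-yl gives the first step in this assay that passes the scatter, which reads a 2.1-fold lower number from compound 1 to compound 3 (0.32 log units; beyond the scatter) and so shows that a change at this place can separate two compounds in this assay. Measured against the 2,4-difluorophenyl group, however, the same group gives only a 1.5-fold lower number from compound 2 to compound 3 (0.19 log units; within the scatter) and stays within the scatter, so across these three groups only compound 1 and compound 3 can be told apart, while compound 2 cannot be separated from either. The change also shows that this place accepts a larger group carrying 2 six-membered aromatic rings of carbon only and a hydrogen-bond donor without the number leaving this narrow band, but nothing measured here speaks to the reason for these steps.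

Since the second aromatic ring and the hydroxyl enter together in one group, the compounds shown leave open which of them goes with the step from compound 1, a question that a plain naphthalen-1-yl or a 2-hydroxyphenyl group would address. They also leave open whether a group of another kind at this place, such as an amine or a carboxylic acid, would move the number further than these three groups do.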